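Replacing the 3,5-dimethylphenyl group of compound 1

This account rests on a few compounds, and the source may have more. Where it says the series, first, only, none or still open, it means among the compounds named here.

In a functional assay on DU-145 cells (Homo sapiens) for inhibition, read by trypan blue exclusion, with a stated time of 96 h (a higher number here means a weaker inhibitor of growth, a lower number a stronger inhibitor of growth), compound 1 `Cc1cc(C)cc(/C=C(/Sc2ccc(Br)cc2)C(=O)c2ccc(Cl)cc2)c1` gives 10000 nM and holds the lower of two numbers, while compound 2 `Cc1ccc(S/C(=C/c2cc(C)cc(C)c2)C(=O)c2ccc(Cl)cc2)cc1` gives 50000 nM there. Compound 3 `COc1ccc(/C=C(/Sc2ccc(Br)cc2)C(=O)c2ccc(Cl)cc2)cc1` awaits measurement and carries 4-methoxyphenyl in place of 3,5-dimethylphenyl on a double-bonded chain carbon bound to a double-bonded chain carbon on a double-bonded chain carbon. Among the compounds with values here, the only measured step of a 5.0-fold higher number from compound 1 to compound 2 (0.70 log units; beyond the scatter) swaps bromo for methyl at another place, so it shows a size that one change can reach but gives no direction for this one. No shift beyond the scatter is therefore expected, and the estimated step is a 1.3-fold lower number from compound 1 to compound 3 (0.10 log units; within the scatter) in this reading. For compound 3 the expected value is 8000 nM within an estimated range of 2000 nM to 32000 nM in this assay.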

Compound 3, concentration for 50% growth inhibition: 50000 nM
Compound 3: the middle estimate sits 6.3-fold (0.80 log units) below what was measured; measured number above the stated range.
By their numbers in this assay, from the lowest: compound 1; then compounds 2 and 3 (each within the scatter of the next).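

In this assay the step of a 5.0-fold higher number from compound 1 to compound 3 (0.70 log units; beyond the scatter) shows that the group on a double-bonded chain carbon bound to a double-bonded chain carbon also moves the number, as until now only the swap of bromo for methyl at another place had done. Here 4-methoxyphenyl in place of 3,5-dimethylphenyl, with the same heavy-atom count, gives a weaker inhibitor of growth. No measured evidence accounts for this shift.

The loss of the two methyl groups and the arrival of the methoxy group occur in one swap, so the compounds shown leave their separate shares open. From the compounds shown here alone, whether an amine or a carboxylic acid on this aromatic ring would bring the number back toward that of compound 1 also stays open.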